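A few compounds are considered here, and "the series" means these few. Any claim that something is new, unique, unknown or untested is made for them only; others in the source may bear on it.

Measured compounds:
- compound 1 `COc1ccccc1N1C(=O)CSC1C(=O)NCCCCc1ccccc1`: 0%
- compound 2 `O=C(NCCCCc1ccccc1)c1cccc(C2SCC(=O)N2c2ccccc2)c1`: 55%

Both were run in a functional assay on HOS cells (Homo sapiens) for inhibition, read by CCK-8 assay, with a stated time of 72 h, tested at 1 uM; a lower number here means less inhibition, a higher number more inhibition at the concentration tested (going by the name of the read-out). Among the compounds with values here, compound 1 gives 0%, while compound 2 gives 55%, the higher of the two numbers and a gap beyond the usual scatter; the two structures differ in more than one place, so no single step connects them.

Compound 3 `COc1cccc(OC)c1N1C(=O)CSC1c1cccc(C(=O)NCCCCc2ccccc2)c1` is not yet measured. It is derived from compound 2 by one change: 2,6-dimethoxyphenyl in place of phenyl on an amide-type nitrogen in a ring. The change brings in two methoxy groups on the ring that sits on the amide-type nitrogen. Compound 1 also carries a methoxy on that ring and shows no inhibition, but it differs from compound 2 elsewhere as well, so no direction can be read off from it.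

For compound 3 a moderate drop in inhibition relative to compound 2 is expected, on the order of a number 15 percentage points lower from compound 2 to compound 3 (beyond the scatter), possibly within the scatter. The estimate for compound 3 in this assay is 40%, with a range from 10% to 70%.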

Compound 3, a percentage reported as inhibition, at one concentration (the size of the read-out at that concentration, not a potency): 80%
Estimate against measurement, compound 3: 40 percentage points below, outside the stated range (above it).
By their numbers in this assay, from the lowest: compound 1; then compound 2; then compound 3.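

In this assay, within the data shown here, 2,6-dimethoxyphenyl in place of phenyl on the amide-type nitrogen in the ring gives a number 25 percentage points higher from compound 2 to compound 3 (beyond the scatter) as the first single-place step. This position therefore accepts the two methoxy groups with a gain in inhibition at the concentration tested, and the larger group, with its 10 heavy atoms against 6, does not cost inhibition here. No measurement at hand explains this gain.

Open, on these data alone, is whether a single methoxy on this ring carries the gain, or whether the pair is needed, and whether ethoxy groups or chlorine atoms in place of the methoxy groups would do the same. Also open, as far as these compounds go, is whether the gain persists when the amide side chain ends in an amine or a carboxylic acid instead of phenyl.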